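This account rests on a few compounds, and the source may have more. Where it says the series, first, only, none or still open, it means among the compounds named here.

Working notes on the series. In an ADME assay on microsomes from liver (Mus musculus) for metabolic stability (a higher number here means faster removal of the compound, a lower number slower removal), compound 1 `O=C(NCc1ccc(Cl)cc1)c1ncc2cccnc2c1O` gives 10 mL.min-1.g-1 and compound 2 `Cc1n[nH]c(-c2ncc3c(N(C)C)ccnc3c2O)n1` gives 14 mL.min-1.g-1. Among the compounds with values here, these are the only two numbers available, and they lie within the usual scatter of each other, so compound 2 cannot be separated from compound 1. Compound 3 `Cc1n[nH]c(-c2ncc3c(-c4ccccc4)ccnc3c2O)n1` carries phenyl in place of dimethylamino on an aromatic carbon, opposite the ring nitrogen (phenyl in place of dimethylamino on an aromatic carbon). Within the data shown here, no two measured compounds differ in one place, and the data therefore hold no direct precedent for this exchange. The expectation rests only on the value of compound 2, 14 mL.min-1.g-1, and on the structural change, with wide uncertainty. In this assay, a modest rise is expected, possibly no larger than the scatter, and the estimated step is a 1.4-fold higher number from compound 2 to compound 3 (0.15 log units; within the scatter). For compound 3 the estimate is 20 mL.min-1.g-1, with an expected range of 8 mL.min-1.g-1 to 50 mL.min-1.g-1.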

Compound 3, intrinsic clearance in microsomes: 9.4 mL.min-1.g-1
Compound 3: the middle estimate sits 2.1-fold (0.33 log units) above what was measured; measured number inside the range.
By their numbers in this assay, from the lowest: compounds 3, 1 and 2 (each within the scatter of the next).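

In this assay, within the data shown here, phenyl in place of dimethylamino on this aromatic carbon, opposite the ring nitrogen, gives a 1.5-fold lower number from compound 2 to compound 3 (0.17 log units; within the scatter) as the first step that can be read at a single place. It shows that, on this core, this position can carry a six-membered aromatic ring of carbon only instead of dimethylamino with no step beyond the scatter in this read-out. Nothing on hand accounts for the outcome, which stands as an observation only.

A single step leaves open whether the result is particular to phenyl or also holds at this carbon for other groups, such as a morpholine ring, a carboxylic acid or a plain methyl. On these data alone, whether the same exchange reads alike with the amide side chain of compound 1 in place of the methyl triazole also remains open.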